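The source may hold more compounds than are shown below. What is called first, only, known or untested is meant among the compounds shown, and "the series" means these compounds.

Working notes on the cytotoxicity series. Three amides share a chloro-nitrobenzamide core joined to a thiazole or benzothiazole aryl amine: compound 1 `O=C(Nc1nc(-c2ccc(Cl)cc2)cs1)c1cc([N+](=O)[O-])ccc1Cl`, compound 2 `Cc1ccc(-c2nc3ccccc3s2)cc1NC(=O)c1cc([N+](=O)[O-])c(N2CCCCC2)cc1Cl` and compound 3 `O=C(Nc1cccc(-c2nc3ccccc3s2)c1)c1cc([N+](=O)[O-])c(O)cc1Cl`. In an ADME assay on BJ cells (Homo sapiens) for cytotoxicity, with a stated time of 72 h (on this read-out higher numbers stand for an effect only at larger amounts of compound and lower numbers for an effect already at smaller amounts), compound 1 gives 18000 nM. Compound 2 reaches only the assay limit in this assay, reported as > 25000 nM, and not a number. Compound 3 likewise stops at the limit in this assay, > 25000 nM. Compound 2 therefore stands at the limit of > 25000 nM in this assay, at which 2 of the 3 values shown sit, so no ordering among the three is possible from these figures; nothing separates them beyond the scatter.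

Not yet measured is compound 4 `Cc1ccc(-c2nc3ccccc3s2)cc1NC(=O)c1cc([N+](=O)[O-])ccc1Cl`. Against compound 2 the change is hydrogen in place of piperidin-1-yl on an aromatic carbon. Among the measured compounds shown here, no measured pair in this set differs in one place, so the size of this step is unknown from direct comparison; compound 1, which also carries hydrogen at that position on its core, gives 18000 nM.

The step expected in this assay is an at least 1.1-fold lower number from compound 2 to compound 4 (0.05 log units; that floor lies within the scatter), that is, nothing clearly beyond the scatter, in either direction. Compound 4 is expected to give about 22000 nM, within 10000 nM to 50000 nM, with a fair chance that only a limit is reported.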

Compound 4, half-maximal effective concentration: > 14000 nM
Compound 4 gave a limit, no number; the forecaster's own chance of this, stated with the estimate: 55%; the middle value does not contradict the limit.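

Compound 2 and compound 4 both give only limits and no numbers, so the step between them, hydrogen in place of piperidin-1-yl on an aromatic carbon, cannot be read. The compounds shown leave open whether that change shifts the value in this assay at all, and if so, in which direction and by how much.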